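From methoxy to fluoro: what compound 4 may show

The source may hold more compounds than are shown below. What is called first, only, known or untested is meant among the compounds shown, and "the series" means these compounds.

In a functional assay on MGC-803 cells (Homo sapiens) for antiproliferative activity, read by MTT assay, with a stated time of 72 h (on this read-out lower numbers stand for stronger inhibition and higher numbers for weaker inhibition), compound 1 `Cc1ccccc1-n1nc(-c2ccccc2)nc1CNc1ccc(C(=O)NO)cc1` gives 12300 nM and compound 3 `O=C(NO)c1ccc(NCc2nc(-c3ccccc3)nn2-c2cccc(Cl)c2)cc1` gives 13700 nM as its result. As far as these compounds go, for compound 2 `COc1ccc(-c2nc(CNc3ccc(C(=O)NO)cc3)n(-c3ccccc3)n2)cc1` the result > 20000 nM is a limit and not a number, so its true position stays open.

Compound 4 `O=C(NO)c1ccc(NCc2nc(-c3ccc(F)cc3)nn2-c2ccccc2)cc1` has not been measured. It differs from compound 2 at one place: fluoro in place of methoxy on an aromatic carbon (fluoro in place of methoxy on an aromatic carbon, para to a large group). The group on that ring thus goes from 4-methoxyphenyl to 4-fluorophenyl.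

Among the compounds with values here, only one measured step is available: a 1.1-fold higher number from compound 1 to compound 3 (0.05 log units; within the scatter) and it stays within the scatter. Within the data shown here, that step lies on an aromatic nitrogen, so no measured step covers the methoxy swap itself. Still, compound 1 at 12300 nM and compound 3 at 13700 nM both carry no methoxy group and both return numbers. Compound 4 also lacks methoxy, so a result in the same region is expected, though two compounds are thin ground. The expected change is an at least 1.3-fold lower number from compound 2 to compound 4 (0.12 log units; that floor lies within the scatter) and it is an estimate set against a limit. Compound 4 is estimated at 15000 nM with a range from 7000 nM to 30000 nM and it may yet return only a limit.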

Compound 4, half-maximal inhibitory concentration: 8960 nM
The estimate for compound 4 lay 1.7-fold (0.22 log units) above the measured number, within the range that was stated.
By their numbers in this assay, from the lowest: compounds 4, 1 and 3 (each within the scatter of the next). At a limit, above all of these: compound 2.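

In this assay, within the data shown here, the change on this ring gives the first step at this position that can be sized at all, and it reads an at least 2.2-fold lower number from compound 2 to compound 4 (0.34 log units; beyond the scatter). Among these compounds, the only earlier step lay on an aromatic nitrogen and stayed within the scatter, whereas this one lies on an aromatic carbon, para to a large group, and goes beyond the scatter, so the change from 4-methoxyphenyl to 4-fluorophenyl does register in this read-out. The size of the step is only a floor, since the result for compound 2 is a limit and not a number: the limit of > 20000 nM in this assay, at which 1 of the 4 values shown sits.

As far as these compounds go, this single pair cannot separate the loss of methoxy from the entry of fluoro, so it remains unclear which of the two accounts for the step, and how far the true gap runs also stays unknown. From the compounds shown here alone, what an amine, a carboxylic acid or a longer alkoxy chain would give at this same place stays open, as does whether the same swap would produce a step of similar size on a compound carrying a different group on the aromatic nitrogen.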